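The source may hold more compounds than are shown below. What is called first, only, known or untested is meant among the compounds shown, and "the series" means these compounds.

Three compounds share one core and differ only in the group carried on an amide-type nitrogen. In a functional assay on HepG2 cells (Homo sapiens) for inhibition, read by MTT assay, with a stated time of 72 h (a higher number here means a weaker inhibitor, a lower number a stronger inhibitor), compound 1 `Cc1noc(C)c1-c1cnc(N)c(Oc2ccc(C(=O)NC3CC3)cc2)n1` gives 43200 nM, the highest of the three numbers and therefore the weakest inhibitor of this small set. Compound 2 `Cc1noc(C)c1-c1cnc(N)c(Oc2ccc(C(=O)NC3CCCCC3)cc2)n1`, with cyclohexyl on that nitrogen, gives 5420 nM, and compound 3 `Cc1noc(C)c1-c1cnc(N)c(Oc2ccc(C(=O)Nc3ccc(Cl)cc3)cc2)n1`, with 4-chlorophenyl there, gives 14400 nM. Both steps away from compound 1 lower the number: an 8.0-fold lower number from compound 1 to compound 2 (0.90 log units; beyond the scatter) and a 3.0-fold lower number from compound 1 to compound 3 (0.48 log units; beyond the scatter). Between the two larger groups, a 2.7-fold higher number from compound 2 to compound 3 (0.42 log units; beyond the scatter).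

Compound 4 `Cc1noc(C)c1-c1cnc(N)c(Oc2ccc(C(=O)Nc3cccc(Cl)c3)cc2)n1` has not yet been measured in this assay. Relative to compound 1 the change is 3-chlorophenyl in place of cyclopropyl on an amide-type nitrogen. Going by the values given here, the closest precedent is the step to compound 3, which also places a chlorophenyl on the amide nitrogen and gave a 3.0-fold lower number from compound 1 to compound 3 (0.48 log units; beyond the scatter); the step to compound 2, an 8.0-fold lower number from compound 1 to compound 2 (0.90 log units; beyond the scatter), shows that the other larger group on this nitrogen lowered the number as well. Among these three compounds no step goes the other way. The step is therefore expected to be modest and downward, a 2.9-fold lower number from compound 1 to compound 4 (0.46 log units; beyond the scatter). Compound 4 is estimated at 15000 nM, with a likely range from 5000 nM to 45000 nM, because compound 3 gave 14400 nM with a closely related group.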

Compound 4, half-maximal inhibitory concentration: 7300 nM
Compound 4: middle estimate off by 2.1-fold (0.31 log units), on the high side, and the stated range covers the measured number.
By their numbers in this assay, from the lowest: compounds 2, 4 and 3 (each within the scatter of the next, the first and the last beyond it); then compound 1.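

Replacing cyclopropyl with 3-chlorophenyl gives a 5.9-fold lower number from compound 1 to compound 4 (0.77 log units; beyond the scatter) in this assay, so a third larger group on the amide nitrogen also lowers the number, and no compound shown goes against this. The place of the chlorine on the phenyl ring does not separate these two compounds, as the change from 4-chlorophenyl to 3-chlorophenyl gives a 2.0-fold lower number from compound 3 to compound 4 (0.30 log units; within the scatter) and the printed step stays within the usual scatter. The earlier gap between cyclohexyl and 4-chlorophenyl also does not carry over to every chlorophenyl group, as the change from cyclohexyl to 3-chlorophenyl gives a 1.3-fold higher number from compound 2 to compound 4 (0.13 log units; within the scatter) and these two groups cannot be told apart here.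

Going by these compounds, it remains open what a phenyl ring with no chlorine would give, what a methoxy group, an amine or a carboxylic acid on that ring would give in place of the chlorine, and how a longer carbon chain on the amide nitrogen would compare. Nothing among the data shown accounts for the differences between these numbers.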